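The source may report more compounds than this note shows. Statements on the series, on what has been measured and on what is new or still open speak of the compounds shown alone.

Compound 2 `N=C(N)c1ccc(-c2ccc(-c3ccc(Cl)cc3)o2)o1` gives 97.3% in an ADME assay on cells (Erythrocyte, Homo sapiens) for activation, read by hemolysis, with a stated time of 30 min, tested at 10 mM (a lower number here means a weaker effect, a higher number a stronger effect of the compound at the concentration tested), the top of the two numbers seen so far, though its gap to compound 1 is within the scatter: compound 1 `N=C(N)c1ccc(-c2ccc(-c3ccc(F)cc3)o2)o1` gives 90%, and the step of a number 7.3 percentage points higher from compound 1 to compound 2 (within the scatter) shows how little chloro in place of fluoro on an aromatic carbon changed the read-out. Compound 3 `COc1ccc(-c2ccc(-c3ccc(C(=N)N)o3)o2)cc1` differs from compound 2 by methoxy in place of chloro on an aromatic carbon. Within the data shown here, only that one small step bears on this change, and no methoxy has yet been measured. Compound 3 is therefore expected to land near compound 2, a step of a number 5.3 percentage points lower from compound 2 to compound 3 (within the scatter) within the scatter, with an estimate of 92% ranging from 75% to 100%.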

Compound 3, a percentage reported as activity, at one concentration (the size of the read-out at that concentration, not a potency): 71.7%
Beside the measured number, compound 3's estimate is 20.3 percentage points above it; measured number below the stated range.
By their numbers in this assay, from the lowest: compound 3; then compounds 1 and 2 (each within the scatter of the next).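

On this aromatic carbon, para to a large group, the read-out in this assay does respond to the group present: chloro in place of fluoro stayed within the scatter, but methoxy does not (a number 25.6 percentage points lower from compound 2 to compound 3 (beyond the scatter); a number 18.3 percentage points lower from compound 1 to compound 3 (beyond the scatter)). The two halogen compounds thus stand together, with compound 3 clearly lower. No supporting data explain this drop. As far as these compounds go, it remains open whether a methyl, an amine or a longer chain such as ethoxy would read like the halogens or like methoxy.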